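The source may report more compounds than this note shows. Statements on the series, on what has been measured and on what is new or still open speak of the compounds shown alone.

Working notes on the series. Cytotoxicity is read in a functional assay on HCT-116 cells (Homo sapiens) for cytotoxicity, read by resazurin assay, with a stated time of 48 h; a higher number here means that more compound is needed for the effect, a lower number that less compound is needed. Compound 1 `O=C(Nc1ccc(Sc2nc3ccccc3s2)cc1)c1cc(Br)cc(Br)c1O` gives 19000 nM in this assay. Among the measured compounds shown here, the only other measured compound, compound 2 `O=S(=O)(Nc1ccc(-c2nc3cc(NS(=O)(=O)c4ccc(Cl)s4)ccc3o2)cc1)c1ccc(Cl)c(C(F)(F)F)c1`, gives 17000 nM in this assay; the two numbers sit side by side, the gap between them within the usual scatter, so neither stands apart from the other. For the measured compounds named here, no pair of measured compounds differs in a single place, so no measured step is available to guide the next change.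

Compound 3 `O=C(Nc1ccc(Sc2nc3ccccc3s2)cc1)c1cccc(Br)c1O` is the compound yet to be measured. It differs from compound 1 by hydrogen in place of bromo on an aromatic carbon. With no measured step of this kind in the series, the direction rests on the change alone. The expectation here is a moderate rise in the number, beyond the scatter but not large; the estimated step is a 1.7-fold higher number from compound 1 to compound 3 (0.23 log units; within the scatter). Compound 3 is accordingly expected to give about 32000 nM in this assay, within a range of 12000 nM to 85000 nM.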

Compound 3, half-maximal effective concentration: 8900 nM
Estimate against measurement, compound 3: 3.6-fold (0.56 log units) above, and the stated range ends above it.
By their numbers in this assay, from the lowest: compounds 3, 2 and 1 (each within the scatter of the next, the first and the last beyond it).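

Taking the bromo group off this aromatic carbon, para to the hydroxy group, turns 3,5-dibromo-2-hydroxyphenyl into 3-bromo-2-hydroxyphenyl and gives the first measured step in the series, with a 2.1-fold lower number from compound 1 to compound 3 (0.33 log units; beyond the scatter) in this assay for the loss of this one heavy atom. The step is modest but beyond the scatter, so this position does affect the read-out, and the bromo group there is not required for cytotoxicity in these cells. The data shown offer no measured basis for explaining the step.

Going by these compounds, how an amine, a methoxy group or a carboxylic acid at this position would compare remains open. So does the effect of changing the remaining bromo group or the hydroxy group on the same core.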